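Notes on the sulfanyl chain of compound 2

The source may hold more compounds than are shown below. What is called first, only, known or untested is meant among the compounds shown, and "the series" means these compounds.

Measured so far in a functional assay on ECa-109 cells (Homo sapiens) for antiproliferative activity, read by MTT assay, with a stated time of 72 h; a lower number here means a stronger inhibitor, a higher number a weaker inhibitor:
compound 1, `CCCSc1nc(N/N=C(\C)c2ccc(OC)cc2)c2nnn(Cc3ccccc3)c2n1`: > 64000 nM, a limit of the assay
compound 2, `C#CCSc1nc(N/N=C(\C)c2ccccc2O)c2nnn(Cc3ccccc3)c2n1`: 5250 nM
compound 3, `C#CCSc1nc(N/N=C/c2c(O)ccc3ccccc23)c2nnn(Cc3ccccc3)c2n1`: 6520 nM

Compound 2 gives the lower of the two numbers shown, and compound 3 stands within the scatter of it, so no order between the two is drawn. For compound 1 only a limit of the assay is reported.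

Compound 4, `CCCSc1nc(N/N=C(\C)c2ccccc2O)c2nnn(Cc3ccccc3)c2n1`, differs from compound 2 by ethyl in place of ethynyl on a saturated chain carbon bound to a sulfur. Among the measured compounds shown here, no measured pair differs by this change alone; compound 1 also carries propylsulfanyl, but its hydrazone part differs as well, so it gives no clean step. A moderate loss is expected on saturating the chain, somewhat beyond the scatter. For compound 4 the estimate is 15000 nM, range 4000 nM to 60000 nM, which means an expected step of a 2.9-fold higher number from compound 2 to compound 4 (0.46 log units; beyond the scatter).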

Compound 4, half-maximal inhibitory concentration: 11100 nM
Compound 4: the middle estimate sits 1.4-fold (0.13 log units) above what was measured; the measured number falls inside the stated range.
By their numbers in this assay, from the lowest: compounds 2, 3 and 4 (each within the scatter of the next, the first and the last beyond it). At a limit, above all of these: compound 1.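

In this assay, the change from propargyl to propyl now has a clean reading, with a 2.1-fold higher number from compound 2 to compound 4 (0.33 log units; beyond the scatter), so this position responds to the triple bond, though modestly. With propylsulfanyl held constant, 2-hydroxyphenyl in place of 4-methoxyphenyl gives an at least 5.7-fold lower number from compound 1 to compound 4 (0.76 log units; beyond the scatter). That step rests on a limit of the assay for compound 1, so its full size stays unknown: the limit of > 64000 nM in this assay, at which 1 of the 4 values shown sits.

Still open, from the compounds shown here alone, is whether a longer chain, such as butyl, or a terminal amine on the sulfanyl chain would hold the number of compound 2. Going by these compounds, whether the propargyl to propyl step carries over to the hydrazone part of compound 3 is also open.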